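The compounds below may be only part of what the source reports. "The series", "measured", "known", "first", "only" and "open" are said of these compounds alone.

The compounds measured so far, with their results in a functional assay on A549 cells (Homo sapiens) for inhibition, read by MTT assay, with a stated time of 48 h; on this read-out lower numbers stand for stronger inhibition and higher numbers for weaker inhibition:

Compound 1 `COc1ccc(N(C)c2nc(C)nc3ccccc23)cc1OCCN`: 122 nM
Compound 2 `COc1ccc(N(C)c2nc(C)nc3ccccc23)cc1C(=O)OCC[Se]C#N`: 353 nM
Compound 3 `COc1ccc(N(C)c2nc(C)nc3ccccc23)cc1OCCCCCC[Se]C#N`: 5520 nM

Compound 3 gives the highest number of the three, that is, the weakest inhibition in this assay; compound 2 lies nearest to it, with a 16-fold higher number from compound 2 to compound 3 (1.19 log units; beyond the scatter), and compound 1 lies furthest, with a 45-fold higher number from compound 1 to compound 3 (1.66 log units; beyond the scatter). Compound 4 `COc1ccc(N(C)c2nc(C)nc3ccccc23)cc1C[Se]C#N` has not yet been measured. It differs from compound 3 in one place: a group of 4 heavy atoms (2 carbon, 1 nitrogen, 1 selenium; no ring) in place of a group of 10 heavy atoms (7 carbon, 1 nitrogen, 1 oxygen, 1 selenium; no ring), on an aromatic carbon. Among the measured compounds shown here, the measured step that bears most on this change is the one in which the group of 8 heavy atoms gave way to the group of 10 heavy atoms, and the number rose: a 16-fold higher number from compound 2 to compound 3 (1.19 log units; beyond the scatter). Compound 4 carries the smallest selenium-bearing group of the four, so the reverse movement is expected, and the step is estimated as a 14-fold lower number from compound 3 to compound 4 (1.14 log units; beyond the scatter). For compound 4 the expected value in this assay is 400 nM, with a range from 130 nM to 1300 nM.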

Compound 4, half-maximal inhibitory concentration: 98 nM
Compound 4: middle estimate off by 4.1-fold (0.61 log units), on the high side, and the stated range ends above it.
By their numbers in this assay, from the lowest: compounds 4 and 1 (each within the scatter of the next); then compound 2; then compound 3.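

In this assay, the group on this aromatic carbon tolerates a large cut in size: the group of 4 heavy atoms performs far better than the group of 10 heavy atoms (a 56-fold lower number from compound 3 to compound 4 (1.75 log units; beyond the scatter)) and also better than the group of 8 heavy atoms (a 3.6-fold lower number from compound 2 to compound 4 (0.56 log units; beyond the scatter)). Across the three selenium-bearing compounds, the smallest group therefore gives the strongest inhibition, and compound 3, with the largest group, gives the weakest. Compound 4 also cannot be told apart from compound 1, which has no selenium (a 1.2-fold lower number from compound 1 to compound 4 (0.10 log units; within the scatter)), so these two different groups of 4 heavy atoms give results within the usual scatter.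

No measurement shown here explains these differences. From the compounds shown here alone, it remains open whether a sulfur atom in place of selenium, or a plain nitrile on the same aromatic carbon, would give a similar result.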